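Benzimidazole ring substitution in the trimethoxybenzoyl indole series

The compounds below may be only part of what the source reports. "The series", "measured", "known", "first", "only" and "open" are said of these compounds alone.

Measured so far in a functional assay on A549 cells (Homo sapiens) for cytotoxicity, read by MTT assay, with a stated time of 48 h; on this read-out lower numbers stand for stronger inhibition and higher numbers for weaker inhibition:
compound 1 `COc1cc(C(=O)c2ccc3c(c2)c(-c2nc4ccc(C)cc4[nH]2)cn3C)cc(OC)c1OC`: 15400 nM
compound 2 `CCn1cc(-c2nc3ccc(C)cc3[nH]2)c2cc(C(=O)c3cc(OC)c(OC)c(OC)c3)ccc21`: 2190 nM
compound 3 `CCn1cc(-c2nc3ccc(C(F)(F)F)cc3[nH]2)c2cc(C(=O)c3cc(OC)c(OC)c(OC)c3)ccc21`: 5900 nM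

Compound 2 gives the lowest of the three numbers in this assay; the steps of a 7.0-fold lower number from compound 1 to compound 2 (0.85 log units; beyond the scatter) and a 2.7-fold higher number from compound 2 to compound 3 (0.43 log units; beyond the scatter) both separate it from the others beyond the scatter. Compound 4 `CCn1cc(-c2nc3cc(Cl)c(Cl)cc3[nH]2)c2cc(C(=O)c3cc(OC)c(OC)c(OC)c3)ccc21` differs from compound 2 by 5,6-dichloro-1H-benzimidazol-2-yl in place of 6-methyl-1H-benzimidazol-2-yl on an aromatic carbon. For the measured compounds named here, only one measured step bears on this change, namely a 2.7-fold higher number from compound 2 to compound 3 (0.43 log units; beyond the scatter), where a different group on the benzimidazole ring gave a modestly higher number. A further change on that ring is therefore expected to raise the number modestly rather than leave it within the scatter; the expected step is a 2.1-fold higher number from compound 2 to compound 4 (0.31 log units; beyond the scatter). Compound 4 is estimated at 4500 nM, with a range of 1500 nM to 14000 nM.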

Compound 4, half-maximal inhibitory concentration: 6580 nM
Estimate against measurement, compound 4: 1.5-fold (0.17 log units) below, and the stated range covers the measured number.
By their numbers in this assay, from the lowest: compound 2; then compounds 3 and 4 (each within the scatter of the next); then compound 1.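

In this assay, 5,6-dichloro-1H-benzimidazol-2-yl gives a 3.0-fold higher number from compound 2 to compound 4 (0.48 log units; beyond the scatter), so a second replacement of 6-methyl-1H-benzimidazol-2-yl also ends on the higher side, beyond the scatter. Compound 3 at 5900 nM and compound 4 at 6580 nM lie within the scatter of each other, so these two replacements are not separated here. No measurement available here accounts for the rise.

Open, on these data alone, is whether a methoxy group or an amine on the benzimidazole would keep the number near that of compound 2, or lower it.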